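This account rests on a few compounds, and the source may have more. Where it says the series, first, only, none or still open, it means among the compounds named here.

Working notes on the series. Within the data shown here, compound 1 `CS(=O)(=O)c1ccc(-n2nc(C(F)(F)F)cc2-c2ccccc2)nc1` is the one compound of the set with a number: in a physicochemical assay for solubility (on this read-out higher numbers stand for higher solubility and lower numbers for lower solubility), compound 1 gives 50 ug/mL. Compound 2 `CC1CCCN(c2cc(C(F)(F)F)nn2-c2ccc(S(C)(=O)=O)cn2)C1` has no reported result in this assay: its entry reads "not determined" (no result reported). Among the measured compounds shown here, compound 3 `CS(=O)(=O)c1ccc(-n2nc(C(F)(F)F)cc2NC2CCC2)nc1` likewise stands without a number in this assay, its entry reading "not determined" (no result reported), so its place cannot be fixed from measurements; the only anchor is compound 1. Compound 4 `CS(=O)(=O)c1ccc(-n2nc(C(F)(F)F)cc2NC2CCCC2)nc1` is not yet measured. The change from compound 3 to compound 4 is cyclopentyl in place of cyclobutyl on a nitrogen on an aromatic ring. With no measured step of this kind in the set, the step from compound 3 to compound 4 in this assay is expected to stay within the usual scatter, in either direction. For compound 4 an estimate of 30 ug/mL is given, expected to fall between 8 ug/mL and 120 ug/mL.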

Compound 4, solubility: 25 ug/mL
Beside the measured number, compound 4's estimate is 1.2-fold (0.08 log units) above it; low and high end bracket the measured number.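

Compound 4 gives this position its first readable comparison in this assay: cyclopentylamino in place of phenyl on an aromatic carbon gives a 2.0-fold lower number from compound 1 to compound 4 (0.30 log units; within the scatter), so the two groups are not told apart on this read-out. The change from cyclobutylamino to cyclopentylamino cannot be read, since compound 3 stands without a number. Nothing in hand offers an explanation for this result.

Open, from the compounds shown here alone, is whether a morpholine or a carboxylic acid on this aromatic carbon would move the read-out beyond the scatter. Also open, going by these compounds, is whether a longer alkyl chain on the nitrogen would do so.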